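A few compounds are considered here, and "the series" means these few. Any claim that something is new, unique, unknown or untested is made for them only; others in the source may bear on it.

Compound 1 `O=C(O)c1nc(-c2ccccc2)n(-c2cccc(Cl)c2F)c1-c1ccc(F)c(Cl)c1`, compound 2 `Cc1ccc(Cl)cc1-n1c(-c2ccccc2)nc(C(=O)O)c1-c1cccc(Cl)c1` and compound 3 `O=C(O)c1nc(C2CCCCC2)n(-c2cccc(Cl)c2F)c1-c1ccc(F)c(Cl)c1` all carry a carboxy group on the shared core. In a functional assay on SAOS-2 cells (Homo sapiens) for antiproliferative activity, read by fluorescence, with a stated time of 72 h (a higher number here means a weaker inhibitor, a lower number a stronger inhibitor), compound 1 gives only a limit, > 30000 nM. Compound 2 likewise reaches only a limit in this assay, > 30000 nM. Compound 3 also gives a limit, > 30000 nM. All three values sit at the limit of > 30000 nM in this assay, at which 3 of the 3 values shown sit, and the step that the two limits leave unreadable from compound 1 to compound 3 is therefore unreadable. Compound 4 `NC(=O)c1nc(C2CCCCC2)n(-c2cccc(Cl)c2F)c1-c1ccc(F)c(Cl)c1` differs from compound 3 by amino in place of hydroxy on a carbonyl carbon. Going by the values given here, no measured pair shows what amino in place of hydroxy on a carbonyl carbon does in this assay, so no direction can be drawn. Compound 4 is expected to give about 30000 nM, between 6000 nM and 100000 nM, most likely again as a limit. The expected step of a number no higher from compound 3 to compound 4 (the limit leaves the size open) is estimated as none beyond the scatter.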

Compound 4, half-maximal inhibitory concentration: 29000 nM
The estimate for compound 4 lay 1.0-fold (0.01 log units) above the measured number; the range from low to high includes it.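

Replacing hydroxy with amino on the carbonyl carbon, which turns carboxy into carbamoyl, gives in this assay an at least 1.0-fold lower number from compound 3 to compound 4 (0.01 log units; that floor lies within the scatter). Going by these compounds alone, this floor shows no gain beyond the scatter, and the true size of the step stays unreadable, but compound 4 is the first compound here with a measured number rather than a limit. Limits still dominate the series: the limit of > 30000 nM in this assay, at which 3 of the 4 values shown sit.

On these data alone, whether a methyl ester or a nitrile at this place would give a clearly lower number remains open. So does whether carbamoyl would act the same way on the core of compound 1, with phenyl in place of cyclohexyl.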